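Cytotoxicity Outlook for Compound 3 After Benzyl Loss

The source may report more compounds than this note shows. Statements on the series, on what has been measured and on what is new or still open speak of the compounds shown alone.

Measured compounds:
compound 1, `O=C1c2ccccc2N(COCCO)S(=O)(=O)N1Cc1ccccc1`: 125 ug/mL
compound 2, `O=C1NS(=O)(=O)N(COCc2ccccc2)c2ccccc21`: > 50 ug/mL

In a functional assay on HEL cells (Homo sapiens) (a higher number here means that more compound is tolerated, a lower number that less compound is tolerated), compound 1 gives 125 ug/mL. For compound 2 only a limit is known: in this assay compound 2 gives > 50 ug/mL, a limit of the assay and not a number, and it sits at the limit of > 50 ug/mL in this assay, at which 1 of the 2 values shown sits. Compound 3, `O=C1NS(=O)(=O)N(COCCO)c2ccccc21`, is not yet measured. It differs from compound 2 in one place: hydroxymethyl in place of phenyl on a saturated chain carbon bound to an oxygen on a saturated carbon. Within the data shown here, no measured pair of compounds tracks this change, so its effect in this assay cannot be read from a step. Since compound 2 is tolerated at a level above the limit, the expected step from compound 2 to compound 3 is a step that the limit leaves unreadable from compound 2 to compound 3, which is no more than the usual scatter in either direction. Compound 3 is therefore expected to give about 90 ug/mL, within 45 ug/mL to 200 ug/mL, with a fair chance that only a limit is reported again.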

Compound 3, half-maximal cytotoxic concentration: 112 ug/mL
For compound 3 the middle estimate is 1.2-fold (0.09 log units) below the measured one; measured number inside the range.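

Among these compounds, with compound 3 in hand, the amide-type nitrogen in a ring can be judged for the first time in this assay: with the 2-hydroxyethyl group held constant, hydrogen in place of benzyl gives a 1.1-fold lower number from compound 1 to compound 3 (0.05 log units; within the scatter). On this single pair, then, the benzyl on that nitrogen makes no difference that stands out from the scatter. The change from benzyl to 2-hydroxyethyl on the other side of the molecule still cannot be read, because compound 2 stands only at a limit of the assay: the limit of > 50 ug/mL in this assay, at which 1 of the 3 values shown sits.

What the compounds shown leave open is the real size of that change, which needs a number for compound 2 rather than a limit. Also open, going by these compounds, is how the read-out would respond to an amine or a carboxylic acid in place of hydroxymethyl, or to a longer chain in place of benzyl on the amide-type nitrogen in a ring.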